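Removing the Chloro From a Cytotoxic Amide Side Chain

The source may hold more compounds than are shown below. What is called first, only, known or untested is meant among the compounds shown, and "the series" means these compounds.

Among the measured compounds shown here, compound 1 `O=C(CCl)Nn1c(S)nnc1COc1ccccc1C1=NOC(c2ccc(Cl)cc2Cl)C1` carries the only number in this set for an ADME assay (MDM cells, Homo sapiens) for cytotoxicity, read by resazurin assay, with a stated time of 3 days; a higher number here means a weaker inhibitor, a lower number a stronger inhibitor: compound 1 gives 3.2 ug/mL. For the measured compounds named here, compound 2 `C=CCSc1nnc(COc2ccccc2C2=NOC(c3ccc(Cl)cc3Cl)C2)n1NC(=O)CCl` gave "not determined" (no result reported), and compound 3 `CC(C)CSc1nnc(COc2ccccc2C2=NOC(c3ccc(Cl)cc3Cl)C2)n1NC(=O)CCl` gave "not determined" (no result reported), so no step between measured compounds can be drawn, and compound 1 stands alone. Compound 4 `CC(=O)Nn1c(S)nnc1COc1ccccc1C1=NOC(c2ccc(Cl)cc2Cl)C1` differs from compound 1 at a single spot: hydrogen in place of chloro on a saturated chain carbon bound to a carbonyl carbon. Read one bond further out, the (chloromethyl)carbonyl group becomes acetyl. Nothing measured here tells the size of this change, so the expectation rests on compound 1 alone. Compound 4 is expected to come out a weaker inhibitor, with an estimated step of a 3.8-fold higher number from compound 1 to compound 4 (0.57 log units; beyond the scatter) that goes beyond the usual scatter. The estimate for compound 4 is 12 ug/mL, with a range from 3.5 ug/mL to 45 ug/mL.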

Compound 4, half-maximal inhibitory concentration: 1.3 ug/mL
The estimate for compound 4 lay 9.2-fold (0.97 log units) above the measured number; the measured number lies below the stated range.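

In this assay, putting hydrogen in place of chloro on this saturated chain carbon bound to a carbonyl carbon gives a 2.5-fold lower number from compound 1 to compound 4 (0.39 log units; beyond the scatter) and so a stronger inhibitor, not a weaker one. The chloro is therefore not required for this effect on the cells, since the acetyl compound is the stronger of the pair. Nothing available explains the direction of this step.

Going by these compounds, how a fluoro or an amine on that same carbon, or a longer chain in place of the acetyl, would shift the number stays open. A single step also cannot show whether this change would run the same way on a different core.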